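Ring change on the carbonyl-bound chain carbon of compound 2

The source may report more compounds than this note shows. Statements on the series, on what has been measured and on what is new or still open speak of the compounds shown alone.

For the measured compounds named here, compound 2 `CCOc1ncc(-c2nc(C(F)(F)F)sc2N2CCN(C(=O)Cn3cnc4cccnc43)[C@H](C)C2)cn1` gives 20 nM in a functional assay on U2OS cells for antagonist activity at C-X-C chemokine receptor type 3 (Homo sapiens), read by beta-arrestin recruitment (on this read-out lower numbers stand for stronger inhibition and higher numbers for weaker inhibition), the lowest of the three numbers measured so far. Compound 1 `COc1ccc(-c2nc(C(F)(F)F)sc2N2CCN(C(=O)Cn3cnc4cccnc43)[C@H](C)C2)cc1` gives 131 nM and compound 3 `Cc1ncc(-c2nc(C(F)(F)F)sc2N2CCN(C(=O)Cn3cnc4cccnc43)[C@H](C)C2)cn1` gives 168 nM; the steps of a 6.6-fold lower number from compound 1 to compound 2 (0.82 log units; beyond the scatter) and an 8.4-fold higher number from compound 2 to compound 3 (0.92 log units; beyond the scatter) both lie beyond the scatter, while a 1.3-fold higher number from compound 1 to compound 3 (0.11 log units; within the scatter) stays within it. All three steps concern the aryl group attached to the shared core; the group on the saturated chain carbon bound to the carbonyl carbon is the same in all three compounds.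

Compound 4 `CCOc1ncc(-c2nc(C(F)(F)F)sc2N2CCN(C(=O)Cn3ccc4cccnc43)[C@H](C)C2)cn1` alters exactly that part: a group of 9 heavy atoms (7 carbon, 2 nitrogen; one five-membered aromatic ring with 1 hetero atom, one six-membered aromatic ring with 1 hetero atom) in place of a group of 9 heavy atoms (6 carbon, 3 nitrogen; one five-membered aromatic ring with 2 hetero atoms, one six-membered aromatic ring with 1 hetero atom), on a saturated chain carbon bound to a carbonyl carbon. Going by the values given here, none of the measured steps touches this part of the molecule, so no measured step bears on the change and the data show nothing about how this part responds. In the absence of a relevant step the default expectation is a small move in this assay in either direction, not clearly beyond the scatter, with a wide range to reflect the lack of precedent. The expected step is a 1.5-fold higher number from compound 2 to compound 4 (0.18 log units; within the scatter). Compound 4 is accordingly estimated at 30 nM, with a range from 10 nM to 100 nM.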

Compound 4, half-maximal inhibitory concentration: 47 nM
Estimate against measurement, compound 4: 1.6-fold (0.19 log units) below; measured number inside the range.
By their numbers in this assay, from the lowest: compound 2; then compound 4; then compounds 1 and 3 (each within the scatter of the next).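

In this assay, for the compounds shown here, the group on the saturated chain carbon bound to a carbonyl carbon is not a silent part of the molecule: the step of a 2.4-fold higher number from compound 2 to compound 4 (0.37 log units; beyond the scatter) is modest but beyond the scatter, and it is the first reading at this place. The change is a single atom within a group of 9 heavy atoms, from 6 carbon and 3 nitrogen to 7 carbon and 2 nitrogen, with hydrogen-bond acceptors going from 3 to 2, so even this small edit registers here. Nothing available explains the higher number.

From the compounds shown here alone, whether the same step holds with 4-methoxyphenyl or 2-methylpyrimidin-5-yl in place of 2-ethoxypyrimidin-5-yl remains open. So does the response at this place to a quite different group, such as an amine or a carboxylic acid.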